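The source may report more compounds than this note shows. Statements on the series, on what has been measured and on what is new or still open speak of the compounds shown alone.

Among the compounds with values here, compound 1, with the structure `O=C(C=CNc1cc(-c2ccccc2)nn1-c1ccccc1)c1cccs1`, is one of two compounds measured in a functional assay on HepG2 cells (Homo sapiens) for inhibition, read by MTT assay, with a stated time of 48 h (on this read-out higher numbers stand for weaker inhibition and lower numbers for stronger inhibition), and on these numbers it stands lowest: in this assay compound 1 gives 2420 nM. The other measured compound, compound 2, with the structure `Brc1ccc(-c2ccnc3c2c(-c2ccccc2)nn3-c2ccccc2)cc1`, gives in this assay a value of 49900 nM, a gap from compound 1 that lies well beyond the usual scatter; the two compounds differ in more than one place, so the gap cannot be traced to a single change.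

Compound 3, with the structure `O=C(C=CNc1cc(-c2ccccc2)nn1-c1ccccc1)c1ccc(F)cc1`, has not yet been measured. It differs from compound 1 in one place: 4-fluorophenyl in place of thiophen-2-yl on a carbonyl carbon. The shared core of compound 1 is otherwise kept, as is the chain bearing the carbonyl.

Within the data shown here, no measured pair in this set isolates this kind of change, so the expectation rests on compound 1 alone. Compound 3 is expected to show a step from compound 1 of a 1.3-fold higher number from compound 1 to compound 3 (0.12 log units; within the scatter), a small move toward weaker inhibition that may not exceed the scatter. On that basis compound 3 is estimated at 3200 nM in this assay, within a range from 1200 nM to 8500 nM.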

Compound 3, half-maximal inhibitory concentration: 59900 nM
Estimate against measurement, compound 3: 19-fold (1.27 log units) below, and the stated range ends below it.
By their numbers in this assay, from the lowest: compound 1; then compounds 2 and 3 (each within the scatter of the next).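

In this assay, the group on the carbonyl carbon proves to matter a great deal: 4-fluorophenyl in place of thiophen-2-yl gives a 25-fold higher number from compound 1 to compound 3 (1.39 log units; beyond the scatter) with the rest of the molecule unchanged. Within the data shown here, this is the only comparison in the set that isolates a single place, and it shows that on this core the thiophen-2-yl carbonyl goes with much stronger inhibition than the (4-fluorophenyl)carbonyl, a finding that rests on this one pair. The swap replaces a five-membered aromatic ring with one hetero atom by a six-membered aromatic ring of carbon only that carries fluorine, but nothing measured here says which part of that difference accounts for the step.

The compounds shown leave open whether the loss follows from giving up the thiophen-2-yl ring or from the fluorine, which a plain phenyl, a furan-2-yl or a thiophen-3-yl on the same carbonyl carbon would help to separate. They also leave open how a non-aromatic group on that carbon, such as a cyclohexyl or a methyl, would compare with either ring.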